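The source may report more compounds than this note shows. Statements on the series, on what has been measured and on what is new or still open speak of the compounds shown alone.

Compound 1 `OC[C@H]1O[C@@H](n2cnc3c(S)nccc32)C[C@@H]1O` and compound 2 `OC[C@H]1O[C@@H](n2cnc3c(SCc4ccccc4)nccc32)C[C@@H]1O` share one core; compound 3 `OC[C@H]1OC(n2cnc3c(S)nccc32)[C@H](O)[C@@H]1O` and compound 4 `OC[C@H]1OC(n2cnc3c(SCc4ccccc4)nccc32)[C@H](O)[C@@H]1O` share another. The difference between the two cores is not broken down here. In a functional assay (Homo sapiens) for inhibition of Nucleic Acid, tested at 100 uM (on this read-out lower numbers stand for less inhibition and higher numbers for more inhibition at the one concentration tested (going by the name of the read-out)), compound 1 gives 10% and compound 2 gives 18%. Compound 3 gives 6% in this assay. The change benzyl in place of hydrogen on a sulfur produced a number 8 percentage points higher from compound 1 to compound 2 (within the scatter). The same change, (benzyl in place of hydrogen on a sulfur), leads from compound 3 to compound 4, with the place described in identical words for both pairs, so it is the same change made on a different core. Compound 4 has not yet been measured in this assay. A step like a number 8 percentage points higher from compound 3 to compound 4 (within the scatter) is expected, resting on the step seen between compound 1 and compound 2, a number 8 percentage points higher from compound 1 to compound 2 (within the scatter). For compound 4 the estimate in this assay is 14%, within a range of 4% to 26%.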

Compound 4, a percentage reported as inhibition, at one concentration (the size of the read-out at that concentration, not a potency): 30%
For compound 4 the middle estimate is 16 percentage points below the measured one, and the stated range ends below it.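

Benzyl in place of hydrogen on a sulfur gives a number 24 percentage points higher from compound 3 to compound 4 (beyond the scatter) in this assay. The size of the step does not carry over unchanged from one core to the other: the same change on two cores in this assay, a number 8 percentage points higher (within the scatter) from compound 1 to compound 2 and a number 24 percentage points higher (beyond the scatter) from compound 3 to compound 4, 16 percentage points apart, beyond the scatter of two such steps. This rests on a single pair on each core, so it sets no rule for other cores and does not show which feature of the two cores goes with the different steps.

The compounds shown leave open whether other groups on the sulfur, such as methyl, a longer alkyl chain, or a benzyl bearing an amine or a carboxylic acid, would differ between the two cores in the same way. Also open, as far as these compounds go, is how these compounds read at other concentrations.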